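A few compounds are considered here, and "the series" means these few. Any claim that something is new, unique, unknown or untested is made for them only; others in the source may bear on it.

Going by the values given here, compound 2, `COc1cc(NC(=O)NOCCCCCC(=O)NO)c2nccc(C)c2c1`, is one of two compounds measured so far in an ADME assay on isolated protein for inhibition of histone deacetylase 8 (Homo sapiens), read by fluorescence, with a stated time of 90 min; on this read-out higher numbers stand for weaker inhibition and lower numbers for stronger inhibition. In this assay compound 2 gives 1220 nM, the higher of the two numbers, though by a margin that means little: its nearest neighbour is compound 1, `COc1cc(NC(=O)NOCCCCCC(=O)NO)c2ncccc2c1`, which in this assay gives 1080 nM, and the step of a 1.1-fold higher number from compound 1 to compound 2 (0.05 log units; within the scatter) lies within the scatter, so the two values cannot be told apart.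

The next compound, compound 3, `COc1cc(NC(=O)NOCCCCCC(=O)NO)c2nc(OC)cc(C)c2c1`, differs from compound 2 in one place: methoxy in place of hydrogen on an aromatic carbon, the new group sitting next to the ring nitrogen and meta to the methyl group. Among the compounds with values here, the single measured step that offers any guidance, adding a methyl to the shared core, gave a 1.1-fold higher number from compound 1 to compound 2 (0.05 log units; within the scatter) — no shift beyond the scatter. That step concerns a different group at a different carbon, so it speaks only indirectly to a methoxy entering here.

On this thin basis the step of a 1.1-fold higher number from compound 2 to compound 3 (0.06 log units; within the scatter) is expected to stay within the scatter, with no clear direction. For compound 3 the estimated value is 1400 nM, within a range from 600 nM to 3500 nM.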

Compound 3, half-maximal inhibitory concentration: 1540 nM
Compound 3: the middle estimate sits 1.1-fold (0.04 log units) below what was measured; low and high end bracket the measured number.
By their numbers in this assay, from the lowest: compounds 1, 2 and 3 (each within the scatter of the next).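

In this assay, placing a methoxy in place of hydrogen on the aromatic carbon next to the ring nitrogen gives a 1.3-fold higher number from compound 2 to compound 3 (0.10 log units; within the scatter). Going by these compounds alone, this is the first information about this carbon, and it shows that a group of 2 heavy atoms, with an oxygen joined to the ring, can enter here without a change that can be told from the scatter. Neither change to the ring, the methyl nor the methoxy, has yet separated one compound from another, as compounds 1, 2 and 3 each lie within the scatter of the next. No measurement shown here offers an explanation for this outcome.

As far as these compounds go, it remains open whether a different group on this same carbon, such as an amine, a carboxylic acid or a longer chain like butoxy, would move the number beyond the scatter, or whether this position simply has little influence on the read-out. Also open, from the compounds shown here alone, is whether methoxy on this carbon would give the same result on the core of compound 1, which lacks the methyl group.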